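Acetyl in place of phenoxy: notes on compound 4

The compounds below may be only part of what the source reports. "The series", "measured", "known", "first", "only" and "open" are said of these compounds alone.

Measured in an ADME assay on CHO-K1 cells (Cricetulus griseus) for cytotoxicity, read by MTT assay, with a stated time of 24 h (a higher number here means that more compound is tolerated, a lower number that less compound is tolerated), so far:
compound 1 `S=C(Nc1ccccc1)Nc1ccc2[nH]ccc2c1` gives 337000 nM
compound 2 `OCc1ccc(NC(=S)Nc2ccc3[nH]ccc3c2)cc1` gives 1080000 nM
compound 3 `S=C(Nc1ccc(Oc2ccccc2)cc1)Nc1ccc2[nH]ccc2c1` gives 36000 nM

Compound 3 stands lowest of the three, with compound 1 nearest and compound 2 furthest off. Compound 4 `CC(=O)c1ccc(NC(=S)Nc2ccc3[nH]ccc3c2)cc1` has acetyl in place of phenoxy on an aromatic carbon, para to a large group. The counted difference is acetyl in place of phenoxy on an aromatic carbon and nothing else in the structure changes.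

Among the measured compounds shown here, three measured steps bear on this. Phenoxy in place of hydrogen gave a 9.4-fold lower number from compound 1 to compound 3 (0.97 log units; beyond the scatter) as a modest drop. Hydroxymethyl in place of hydrogen gave a 3.2-fold higher number from compound 1 to compound 2 (0.51 log units; beyond the scatter) as a modest rise. Phenoxy in place of hydroxymethyl gave a 30-fold lower number from compound 2 to compound 3 (1.48 log units; beyond the scatter) as a large drop. For the measured compounds named here, no compound with acetyl has been measured, so this reading rests on few points. Of the three, only compound 3 at 36000 nM carries phenoxy. With phenoxy gone, most of the gap to compound 1 is expected to close, so a clear rise in this assay is expected rather than no change. The estimated step is an 8.3-fold higher number from compound 3 to compound 4 (0.92 log units; beyond the scatter) in the upward direction. The estimate for compound 4 is 300000 nM with a range from 100000 nM to 900000 nM expected.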

Compound 4, concentration lethal to 50% of the cells: 154000 nM
Estimate against measurement, compound 4: 1.9-fold (0.29 log units) above; low and high end bracket the measured number.
By their numbers in this assay, from the lowest: compound 3; then compound 4; then compound 1; then compound 2.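

In this assay acetyl in place of phenoxy on an aromatic carbon para to a large group gives a 4.3-fold higher number from compound 3 to compound 4 (0.63 log units; beyond the scatter) and so removes only part of the drop seen with phenoxy. Acetyl in place of hydrogen gives a 2.2-fold lower number from compound 1 to compound 4 (0.34 log units; beyond the scatter) as a further result, which shows that at this position a lower number does not require the six-membered aromatic ring that phenoxy brings, since acetyl has no ring. Acetyl in place of hydroxymethyl gives a 7.0-fold lower number from compound 2 to compound 4 (0.85 log units; beyond the scatter) and places the two ringless groups on opposite sides of compound 1, so that the direction of change here depends on the group entering and not only on whether it carries a ring, with compound 2 standing against any reading that every group at this place lowers the number.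

No measured evidence on hand accounts for these steps, so the difference between acetyl and hydroxymethyl remains unexplained. On these data alone, it remains open where an amine, a carboxylic acid or a longer chain at this same position would fall relative to hydroxymethyl and acetyl in this assay.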